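Dichlorophenyl to Iodomethylphenyl on a Shared Core

This account rests on a few compounds, and the source may have more. Where it says the series, first, only, none or still open, it means among the compounds named here.

Compound 1, `CCCCN(CC)c1cc(C)nc2c1NC(=O)CN2c1ccc(Cl)cc1Br`, gives 2.5 nM in an assay on HEK-293T cells for displacement of a labelled ligand from corticotropin-releasing factor receptor 1 (Homo sapiens), read by scintillation counting, with a stated time of 2 h; on this read-out higher numbers stand for weaker inhibition and lower numbers for stronger inhibition.
Compound 2, `CCCCN(CC)c1cc(C)nc2c1NC(=O)CN2c1ccc(Cl)cc1Cl`, gives 3.4 nM in this assay.

Among the measured compounds shown here, compound 2 holds the higher of the two numbers so far, but the one step that links it to a measured neighbour, a 1.4-fold higher number from compound 1 to compound 2 (0.13 log units; within the scatter), lies within the scatter, so the two compounds cannot be ordered on this assay. Compound 3, `CCCCN(CC)c1cc(C)nc2c1NC(=O)CN2c1ccc(I)cc1C`, has not yet been measured. It differs from compound 2 in one place: 4-iodo-2-methylphenyl in place of 2,4-dichlorophenyl on a nitrogen on an aromatic ring in a ring. For the measured compounds named here, no measured step bears directly on this change. Going by the values given here, the only step available exchanges one halogen for another on the same aromatic carbon and produced no shift beyond the scatter; the change to compound 3 exchanges the whole substituted phenyl and reaches beyond what the measured pair covers, so the direction is not constrained by the data. The step expected for compound 3 is a 1.1-fold lower number from compound 2 to compound 3 (0.05 log units; within the scatter), and it may well stay inside the scatter. Compound 3 is therefore estimated at 3 nM in this assay, with a range from 1 nM to 10 nM.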

Compound 3, inhibition constant: 3.4 nM
Compound 3: middle estimate off by 1.1-fold (0.05 log units), on the low side, and the stated range covers the measured number.
By their numbers in this assay, from the lowest: compounds 1, 2 and 3 (each within the scatter of the next).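

At this place, on a nitrogen on an aromatic ring in a ring, 4-iodo-2-methylphenyl in place of 2,4-dichlorophenyl gives no change at the digits printed from compound 2 to compound 3 (within the scatter) in this assay, and 4-iodo-2-methylphenyl in place of 2-bromo-4-chlorophenyl gives a 1.4-fold higher number from compound 1 to compound 3 (0.13 log units; within the scatter) there. The earlier pair covered only one halogen exchanged for another on a single aromatic carbon, whereas these steps exchange the whole substituted phenyl, with methyl and iodo entering together, and the three compounds still cannot be ordered on this read-out. No evidence is available on why these substituted phenyl groups read alike.

The phenyl groups shown carry only halogens and methyl, so it remains open whether a methoxy group, a nitrile or an amine on this phenyl, or a pyridine ring in its place, would stay within the same scatter. Compound 3 also differs from compound 2 in two substituents at once, so the compounds shown leave open what the methyl or the iodo would do alone.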